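This account rests on a few compounds, and the source may have more. Where it says the series, first, only, none or still open, it means among the compounds named here.

Compound 1 `COc1cc(/C=C/C(=O)/C=C/c2cc(OC)c(OC)c(OC)c2)ccc1OCc1cn(CCOc2cc(=O)oc3ccccc23)nn1` and compound 2 `COc1ccc(/C=C/C(=O)/C=C/c2ccc(OCc3cn(CCOc4cc(=O)oc5ccccc45)nn3)c(OC)c2)cc1OC` share one core; their only counted difference is methoxy in place of hydrogen on an aromatic carbon. In a functional assay on COLO 205 cells (Homo sapiens) for cytotoxicity, read by sulforhodamine B assay, with a stated time of 48 h (a lower number here means a stronger inhibitor, a higher number a weaker inhibitor), compound 2 gives 6780 nM, and compound 1 gives 4680 nM, a step of a 1.4-fold lower number from compound 2 to compound 1 (0.16 log units; within the scatter). Compound 3 `COc1ccc(/C=C/C(=O)/C=C/c2ccc(OCc3cn(CCCOc4cc(=O)oc5ccccc45)nn3)c(OC)c2)cc1OC` stands on another core, and the difference between the two cores is not broken down here. In this assay compound 3 gives 13000 nM; its gap to compound 2 lies within the scatter, its gap to compound 1 beyond it. Compound 4 `COc1cc(/C=C/C(=O)/C=C/c2cc(OC)c(OC)c(OC)c2)ccc1OCc1cn(CCCOc2cc(=O)oc3ccccc23)nn1` is not yet measured. From compound 3 it differs by methoxy in place of hydrogen on an aromatic carbon, and the place reads word for word as for the change from compound 2 to compound 1, so this is the same change, made twice among these compounds and measured once. For compound 4 the step expected in this assay is a 1.4-fold lower number from compound 3 to compound 4 (0.15 log units; within the scatter), because a 1.4-fold lower number from compound 2 to compound 1 (0.16 log units; within the scatter) lies within the scatter and gives no ground to expect more than a small shift. Compound 4 is therefore estimated at 9300 nM, with a range from 4500 nM to 19000 nM.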

Compound 4, half-maximal inhibitory concentration: 10600 nM
Beside the measured number, compound 4's estimate is 1.1-fold (0.06 log units) below it; the measured number falls inside the stated range.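

In this assay the change from 3,4-dimethoxyphenyl to 3,4,5-trimethoxyphenyl on the core of compound 3 gives a 1.2-fold lower number from compound 3 to compound 4 (0.09 log units; within the scatter) and reads the same as on the core of compound 1: the same change on two cores in this assay, a 1.4-fold lower number (0.16 log units; within the scatter) from compound 2 to compound 1 and a 1.2-fold lower number (0.09 log units; within the scatter) from compound 3 to compound 4, 1.2-fold (0.07 log units) apart, within the scatter of two such steps

Both steps lie within the scatter, so the agreement shows only that this methoxy produces no shift that can be told from noise on either core, not that a small real gain carries over from one core to the other. Two pairs in a single cell assay also do not show that the same would hold on any core beyond these two.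

Open, from the compounds shown here alone, is what other groups would do at this place on the aromatic ring, such as a hydroxyl, a chlorine or an amine in place of the added methoxy. For the compounds shown here, also open is whether the change stays as small with a longer chain than the one in compound 3 and compound 4.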